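Trifluoromethyl for Methyl on a Dibrominated Core

A few compounds are considered here, and "the series" means these few. Any claim that something is new, unique, unknown or untested is made for them only; others in the source may bear on it.

Measured compounds:
compound 1, `Cc1ccc(CO/N=C2/C(c3c[nH]c4ccccc34)=Nc3ccccc32)cc1`: 23500 nM
compound 2, `Cc1ccc(CO/N=C2/C(c3c[nH]c4ccc(Br)cc34)=Nc3ccc(Br)cc32)cc1`: 21400 nM
compound 3, `FC(F)(F)c1ccc(CO/N=C2/C(c3c[nH]c4ccccc34)=Nc3ccccc32)cc1`: 18900 nM

In a functional assay on T-24 cells (Homo sapiens) for cytotoxicity, read by MTT assay, with a stated time of 2 days (on this read-out higher numbers stand for weaker inhibition and lower numbers for stronger inhibition), compound 1 gives 23500 nM. Compound 3, `FC(F)(F)c1ccc(CO/N=C2/C(c3c[nH]c4ccccc34)=Nc3ccccc32)cc1`, differs from compound 1 by trifluoromethyl in place of methyl on an aromatic carbon, and this brought a 1.2-fold lower number from compound 1 to compound 3 (0.09 log units; within the scatter). Compound 2, `Cc1ccc(CO/N=C2/C(c3c[nH]c4ccc(Br)cc34)=Nc3ccc(Br)cc32)cc1`, carries a different core; how its core differs from that of compound 1 is not broken down here, and in this assay compound 2 gives 21400 nM, which sits alongside the values of compound 1 and compound 3 without a step beyond the scatter among the three.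

Compound 4, `FC(F)(F)c1ccc(CO/N=C2/C(c3c[nH]c4ccc(Br)cc34)=Nc3ccc(Br)cc32)cc1`, has not yet been measured. It differs from compound 2 by trifluoromethyl in place of methyl on an aromatic carbon, the same change made from compound 1 to compound 3. Because that earlier step was a 1.2-fold lower number from compound 1 to compound 3 (0.09 log units; within the scatter), the same change on compound 2 is expected to give a 1.2-fold lower number from compound 2 to compound 4 (0.08 log units; within the scatter) in this assay. On this basis compound 4 is estimated at 18000 nM, with a likely range from 9000 nM to 40000 nM.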

Compound 4, half-maximal inhibitory concentration: 9880 nM
Estimate against measurement, compound 4: 1.8-fold (0.26 log units) above; the measured number falls inside the stated range.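

In this assay, for the compounds shown here, trifluoromethyl in place of methyl on the core of compound 2 gave a 2.2-fold lower number from compound 2 to compound 4 (0.34 log units; beyond the scatter), a modest step and the only one of the pair that clears the scatter. Set beside the same change on the core of compound 1, the step points the same way and the two do not separate, so the change carries over between these two cores without a demonstrable difference in size: the same change on two cores in this assay, a 1.2-fold lower number (0.09 log units; within the scatter) from compound 1 to compound 3 and a 2.2-fold lower number (0.34 log units; beyond the scatter) from compound 2 to compound 4, 1.7-fold (0.24 log units) apart, within the scatter of two such steps. This does not show that the core of compound 2 responds more strongly than the core of compound 1, and two cores give no rule for any other core in the series.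

The compounds shown leave open how a methoxy, a nitrile or a carboxylic acid would read at the same place, para to a large group, in place of methyl or trifluoromethyl. They also leave open whether the step between 4-methylbenzyl and 4-(trifluoromethyl)benzyl holds in any read-out other than this assay.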